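Halogen swap on the shared core: chloro after bromo

The compounds below may be only part of what the source reports. "The series", "measured", "known", "first", "only" and "open" are said of these compounds alone.

Compound 2 `CCOc1ccc(C(=O)/C=C/c2ccc(Br)cc2)cc1` gives 210 nM in an assay on isolated protein for inhibition of Amine oxidase [flavin-containing] B (Homo sapiens) (on this read-out lower numbers stand for stronger inhibition and higher numbers for weaker inhibition), the higher of the two numbers seen so far, while compound 1 `CCOc1ccc(C(=O)/C=C/c2ccc(F)cc2)cc1` gives 53 nM. Going by the values given here, the only measured step, a 4.0-fold higher number from compound 1 to compound 2 (0.60 log units; beyond the scatter), bears directly on the change to compound 3 `CCOc1ccc(C(=O)/C=C/c2ccc(Cl)cc2)cc1`, (chloro in place of bromo on an aromatic carbon), since it is the same halogen position worked through a third halogen. A partial reversal of that rise is expected, a modest downward move that may reach beyond the scatter, a 2.1-fold lower number from compound 2 to compound 3 (0.32 log units; beyond the scatter). Compound 3 is therefore estimated at 100 nM, with a range from 45 nM to 230 nM.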

Compound 3, half-maximal inhibitory concentration: 210 nM
The estimate for compound 3 lay 2.1-fold (0.32 log units) below the measured number; the measured number falls inside the stated range.
By their numbers in this assay, from the lowest: compound 1; then compounds 2 and 3 (each within the scatter of the next).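

The step of no change at the digits printed from compound 2 to compound 3 (within the scatter) in this assay means that chloro and bromo cannot be told apart at this position on an aromatic carbon para to a large group. With a 4.0-fold higher number from compound 1 to compound 3 (0.60 log units; beyond the scatter) the rise seen with bromo is shared by chloro, and fluoro alone stands apart among the three halogens. Nothing on hand accounts for this split.

Going by these compounds alone, only halogens are compared at this position so far. From the compounds shown here alone, whether the lower number belongs to fluoro alone or also extends to hydrogen, a methoxy group or an amine remains open.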